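Hydroxy in Place of Trifluoromethyl at Two Placements

The source may report more compounds than this note shows. Statements on the series, on what has been measured and on what is new or still open speak of the compounds shown alone.

Measured so far:
compound 1, `O=C(Nc1ccc(C(F)(F)F)cc1)C1NCCc2ccccc21`, 4220 nM
compound 2, `O=C(Nc1ccccc1C(F)(F)F)C1NCCc2ccccc21`, a limit only: > 10000 nM
compound 3, `O=C(Nc1ccc(O)cc1)C1NCCc2ccccc21`, 4370 nM

All three were tested in a functional assay on NUGC-3 cells (Homo sapiens) for inhibition, read by sulforhodamine B assay, with a stated time of 48 h; a higher number here means a weaker inhibitor of growth, a lower number a stronger inhibitor of growth. Compound 1 and compound 3 share a core and differ by one change, (hydroxy in place of trifluoromethyl on an aromatic carbon), which gave a 1.0-fold higher number from compound 1 to compound 3 (0.02 log units; within the scatter). Compound 2 has the same atoms as compound 1 joined differently; the difference between the two cores is not broken down here. The value of compound 2 in this assay is a limit of the assay, not a number (the limit of > 10000 nM in this assay, at which 1 of the 3 values shown sits).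

Compound 4, `O=C(Nc1ccccc1O)C1NCCc2ccccc21`, is not yet measured. It differs from compound 2 by hydroxy in place of trifluoromethyl on an aromatic carbon, the same kind of change as from compound 1 to compound 3, though there the group sits para to a large group and here ortho to a large group. The step is expected to be about a step that the limit leaves unreadable from compound 2 to compound 4, resting on the near-flat step a 1.0-fold higher number from compound 1 to compound 3 (0.02 log units; within the scatter). Compound 4 is therefore estimated at 15000 nM, between 6000 nM and 40000 nM, quite possibly again only a limit.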

Compound 4, concentration for 50% growth inhibition: > 10000 nM
Compound 4 ended at the assay's limit; the forecaster's own chance of this, stated with the estimate: 65%; the middle value is on the limit's open side.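

Compound 2 and compound 4 both stand at a limit of this assay, not at a number, so no step between them can be read: the limit of > 10000 nM in this assay, at which 2 of the 4 values shown sit.

The compounds shown leave open whether hydroxy in place of trifluoromethyl changes growth inhibition at all when ortho to a large group.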